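Hydroxy in place of acetamido: an expectation without a readable guide

The compounds below may be only part of what the source reports. "The series", "measured", "known", "first", "only" and "open" are said of these compounds alone.

compound 1 `CCCS(=O)(=O)Nc1cccc2c1CCCC2c1c[nH]cn1`, in an assay on isolated protein (Cricetulus griseus) for binding affinity to Alpha-1B adrenergic receptor (Mesocricetus auratus), read by radioligand binding; on this read-out higher numbers stand for weaker inhibition and lower numbers for stronger inhibition: < 10000 nM
compound 2 `CN(C)S(=O)(=O)Nc1cccc2c1CCCC2c1c[nH]cn1`, in this assay: < 10000 nM
compound 3 `CC(=O)Nc1cccc2c1CCCC2c1c[nH]cn1`, in this assay: < 10000 nM

Each of these figures is a limit of the assay, not a number. Compound 3 therefore stands only at a limit, as do the two others, all sitting at the limit of < 10000 nM in this assay, at which 3 of the 3 values shown sit. The steps a step that the two limits leave unreadable from compound 1 to compound 2, a step that the two limits leave unreadable from compound 1 to compound 3 and a step that the two limits leave unreadable from compound 2 to compound 3 are accordingly unreadable, and none of them can guide the next change. Compound 4 `Oc1cccc2c1CCCC2c1c[nH]cn1` differs from compound 3 by hydroxy in place of acetamido on an aromatic carbon. With no readable step to draw on, compound 4 is expected to give 1000 nM in this assay, with a range from 50 nM to 9000 nM. The step from compound 3 to compound 4 is thus estimated as a step that the limit leaves unreadable from compound 3 to compound 4, with no direction that the data can support.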

Compound 4, inhibition constant: 145 nM
Compound 4: middle estimate off by 6.9-fold (0.84 log units), on the high side; measured number inside the range.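

No step from compound 1, compound 2 or compound 3 to compound 4 can be read, because those three values are limits and not numbers: the limit of < 10000 nM in this assay, at which 3 of the 4 values shown sit.

The compounds shown leave open how far compound 4 stands from compound 3 in this assay, and whether compound 1, compound 2 and compound 3 differ from one another at all.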